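Trimming the long chain of compound 1

The source may hold more compounds than are shown below. What is called first, only, known or untested is meant among the compounds shown, and "the series" means these compounds.

Compound 1 `CCCCCCCCCCCCCCCCCC(=O)Nc1nnc(S[C@@H]2O[C@H](CO)[C@H](O)[C@H](O)[C@H]2O)s1` gives "not active" (no number reported)
Compound 2 `CCCCCC(=O)Nc1nnc(S[C@@H]2O[C@H](CO)[C@H](O)[C@H](O)[C@H]2O)s1` gives "not active" (no number reported)
Compound 3 `CCCCCC(=O)Nc1nnc(S[C@@H]2O[C@H](COC(C)=O)[C@H](OC(C)=O)[C@H](OC(C)=O)[C@H]2OC(C)=O)s1` gives 24400 nM

In an ADME assay on CHO-K1 cells (Cricetulus griseus) for cytotoxicity, read by MTT assay, with a stated time of 24 h (on this read-out lower numbers stand for stronger inhibition and higher numbers for weaker inhibition), compound 1 has no single number: it shares its outcome with compound 2, and only compound 3 gives a measured value. Compound 4 `CCCCCCCCCCCCCCCC(=O)Nc1nnc(S[C@@H]2O[C@H](CO)[C@H](O)[C@H](O)[C@H]2O)s1` has not been measured yet. It comes from compound 1 by one edit of the long chain: hydrogen in place of ethyl on a saturated chain carbon, ten or more bonds along the chain from a carbonyl carbon. For the measured compounds named here, no measured pair shows the size of this kind of change, so the expectation rests on few data. Compound 1 gives "not active" (no number reported) and compound 2 gives "not active" (no number reported) despite their different chain lengths. No step beyond the usual scatter, in either direction, is therefore expected in this assay and compound 4 may well also come back without a number. If a number is reported, compound 4 is estimated at 100000 nM with an expected range of 30000 nM to 300000 nM in this weak region.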

Compound 4, half-maximal inhibitory concentration: "not active" (no number reported)
For compound 4 the study gives words and no number, and the estimate cannot be compared.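

In this assay compound 1 and compound 4 both come back as not active, with no number, so no step can be read between them. How far trading ethyl for hydrogen on the long chain shifts this read-out stays open, and nothing shown explains these outcomes.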